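Side chain swap: compound 3 to compound 4

A few compounds are considered here, and "the series" means these few. Any claim that something is new, unique, unknown or untested is made for them only; others in the source may bear on it.

Values in a functional assay on a cell-free system (plasma, Homo sapiens) for inhibition, with Plasma (Rattus norvegicus) as the target (on this read-out higher numbers stand for weaker inhibition and lower numbers for stronger inhibition), follow
Compound 1 `O=c1cc(N2CCNCC2)oc2ccccc12` gives 240000 nM
Compound 2 `Cc1c(OCc2ccccc2)ccc2c(N3CCNCC3)cc(=O)oc12` gives 1100 nM
Compound 3 `Cc1c(OCc2cccnc2)ccc2c(N3CCNCC3)cc(=O)oc12` gives 1420 nM

Compound 3 stands within the scatter of compound 2, while compound 1 shows a far higher number. Still unmeasured is compound 4 `CCCOc1ccc2c(N3CCNCC3)cc(=O)oc2c1C` with the change ethyl in place of pyridin-3-yl on a saturated chain carbon bound to an oxygen on an aromatic ring in short: ethyl in place of pyridin-3-yl on a saturated chain carbon bound to an oxygen on an aromatic ring. Going by the values given here, one measured step bears on this place: a 1.3-fold higher number from compound 2 to compound 3 (0.11 log units; within the scatter) for the swap of one aromatic ring for another. Among the compounds with values here, no measured compound carries propoxy there, so the evidence is thin. A move of a 1.1-fold higher number from compound 3 to compound 4 (0.02 log units; within the scatter) is expected in this assay and nothing beyond the scatter is anticipated. Compound 4 is estimated at 1500 nM with an expected range from 500 nM to 4500 nM on this read-out.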

Compound 4, half-maximal inhibitory concentration: 7770 nM
For compound 4 the middle estimate is 5.2-fold (0.71 log units) below the measured one, outside the stated range (above it).
By their numbers in this assay, from the lowest: compounds 2 and 3 (each within the scatter of the next); then compound 4; then compound 1.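

In this assay, this place on a saturated chain carbon bound to an oxygen on an aromatic ring responds to the loss of the aromatic ring: a 5.5-fold higher number from compound 3 to compound 4 (0.74 log units; beyond the scatter) and a 7.1-fold higher number from compound 2 to compound 4 (0.85 log units; beyond the scatter). The earlier swap of one aromatic ring for another stayed within the scatter, so it could not show that propoxy reads apart from both ring-bearing side chains. Nothing measured here explains this step. Open, from the compounds shown here alone, is whether an aromatic ring is required at this place, or whether a saturated ring such as cyclohexyl or a longer chain such as hexyl would read like compound 2 and compound 3 rather than compound 4.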